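A Carbamoylphenyl Analogue Awaits Its Cytotoxicity Measurement

The source may report more compounds than this note shows. Statements on the series, on what has been measured and on what is new or still open speak of the compounds shown alone.

Three compounds sharing one core have been examined in an ADME assay on MT4 cells (Homo sapiens) for cytotoxicity, read by MTT assay, with a stated time of 4 days; on this read-out lower numbers stand for higher toxicity in this test and higher numbers for lower toxicity in this test. Compound 1 `CCOC(=O)c1cnc(N2CCN(Cc3cccc(C(F)(F)F)c3)CC2)nc1Oc1c(C)cc(-c2ccc(C#N)cc2)cc1C` carries a 3-(trifluoromethyl)phenyl group on a saturated chain carbon bound to an amine nitrogen in a ring; in this assay compound 1 reaches only the limit > 125000 nM. Compound 2 `CCOC(=O)c1cnc(N2CCN(Cc3cccc(F)c3)CC2)nc1Oc1c(C)cc(-c2ccc(C#N)cc2)cc1C` holds 3-fluorophenyl at that place, and in this assay compound 2 likewise stops at the limit > 125000 nM. Compound 3 `CCOC(=O)c1cnc(N2CCN(Cc3ccccc3C(=O)OC)CC2)nc1Oc1c(C)cc(-c2ccc(C#N)cc2)cc1C` bears 2-(methoxycarbonyl)phenyl there, and in this assay compound 3 also ends at the limit > 125000 nM. Because of this (the limit of > 125000 nM in this assay, at which 3 of the 3 values shown sit), none of the steps can be read: a step that the two limits leave unreadable from compound 1 to compound 2, a step that the two limits leave unreadable from compound 1 to compound 3 and a step that the two limits leave unreadable from compound 2 to compound 3. Compound 2 therefore stands at the same limit as both companions, with no number to set it apart.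

The next compound, compound 4 `CCOC(=O)c1cnc(N2CCN(Cc3ccc(C(N)=O)cc3)CC2)nc1Oc1c(C)cc(-c2ccc(C#N)cc2)cc1C`, differs from compound 2 in one place: 4-carbamoylphenyl in place of 3-fluorophenyl on a saturated chain carbon bound to an amine nitrogen in a ring. For the measured compounds named here, neither of the three measured steps bears a readable size, so the only guidance is that every aromatic substituent tried so far has left the limit untouched. Compound 4 is expected to give 125000 nM, within 50000 nM to 300000 nM. The step of a number no higher from compound 2 to compound 4 (the limit leaves the size open) is accordingly expected to be no step beyond the scatter.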

Compound 4, half-maximal cytotoxic concentration: 66500 nM
The estimate for compound 4 lay 1.9-fold (0.27 log units) above the measured number, and the stated range covers the measured number.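

In this assay, compound 4 is the only compound shown that gives a number rather than a limit, so the change at the saturated chain carbon bound to an amine nitrogen in a ring can now be given a floor: an at least 1.8-fold lower number from compound 2 to compound 4 (0.27 log units; that floor lies within the scatter), an at least 1.8-fold lower number from compound 3 to compound 4 (0.27 log units; that floor lies within the scatter) and an at least 1.8-fold lower number from compound 1 to compound 4 (0.27 log units; that floor lies within the scatter). Each of these floors lies within the scatter, so 4-carbamoylphenyl is not shown to differ beyond it from any of the other groups, and the true sizes of the steps stay open, as do the unreadable steps among the other three compounds: the limit of > 125000 nM in this assay, at which 3 of the 4 values shown sit. Against 3-fluorophenyl, the entering group brings a hydrogen-bond donor and a hydrogen-bond acceptor, but these compounds do not tie the step to either one.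

The compounds shown leave open how large these steps really are, since only a number for compound 1, compound 2 or compound 3 could settle that. They also leave open whether a carboxylic acid or an amine in place of the carbamoyl group would give a number or stay at the limit.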